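Dichlorophenyl Swap on a Triazole-Linked Bicyclic Ketone

The compounds below may be only part of what the source reports. "The series", "measured", "known", "first", "only" and "open" are said of these compounds alone.

In a functional assay on MDA-MB-231 cells (Homo sapiens) for cytotoxicity, read by MTT assay, with a stated time of 48 h (on this read-out lower numbers stand for stronger inhibition and higher numbers for weaker inhibition), compound 2 `O=C1C[C@H](OCc2cn(-c3ccc(F)cc3)nn2)[C@H]2CO[C@@H]1O2` gives 23700 nM. Compound 1 `O=C1C[C@H](OCc2cn(-c3ccc(Cl)cc3)nn2)[C@H]2CO[C@@H]1O2` gives 26100 nM in this assay, and the step of a 1.1-fold lower number from compound 1 to compound 2 (0.04 log units; within the scatter) leaves the two within the usual scatter of each other. Compound 3 `O=C1C[C@H](OCc2cn(-c3cccc(Cl)c3Cl)nn2)[C@H]2CO[C@@H]1O2` differs from compound 2 by 2,3-dichlorophenyl in place of 4-fluorophenyl on an aromatic nitrogen. Going by the values given here, the only measured step touching the aryl ring, a 1.1-fold lower number from compound 1 to compound 2 (0.04 log units; within the scatter), exchanged one halogen for another without a move beyond the scatter; the data hold nothing on two chlorines at these positions. Compound 3 is therefore expected to show a 1.1-fold lower number from compound 2 to compound 3 (0.03 log units; within the scatter), an estimated 22000 nM in this assay, with a range of 8000 nM to 60000 nM.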

Compound 3, half-maximal inhibitory concentration: 26000 nM
Compound 3: the middle estimate sits 1.2-fold (0.07 log units) below what was measured; the range from low to high includes it.
By their numbers in this assay, from the lowest: compounds 2, 3 and 1 (each within the scatter of the next).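

In this assay, the step of a 1.1-fold higher number from compound 2 to compound 3 (0.04 log units; within the scatter) and the step of a 1.0-fold lower number from compound 1 to compound 3 (0.00 log units; within the scatter) show that 2,3-dichlorophenyl on the aromatic nitrogen gives no move beyond the scatter from either single-halogen aryl group. A second chlorine and a different halogen pattern on this ring therefore leave the number unchanged within these three compounds. Nothing available here bears on this result. Still open, from the compounds shown here alone, is whether an amine or a carboxylic acid on the aryl ring, or a longer chain in its place, would shift the number beyond the scatter.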